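A few compounds are considered here, and "the series" means these few. Any claim that something is new, unique, unknown or untested is made for them only; others in the source may bear on it.

Compound 1 `COc1cc(C(=O)c2sc(-c3ccc(Br)cc3)cc2N)cc(OC)c1OC` was tested in a functional assay on FM3A cells (Mus musculus) for antiproliferative activity (on this read-out higher numbers stand for weaker inhibition and lower numbers for stronger inhibition), where compound 1 gives 150 nM. Of the two numbers available it is the higher, but only compound 2 `COc1cc(C(=O)c2sc(-c3ccc(Cl)cc3)cc2N)cc(OC)c1OC` stands beside it, with 90 nM, and the step of a 1.7-fold lower number from compound 1 to compound 2 (0.22 log units; within the scatter), chloro in place of bromo on an aromatic carbon, stays within the scatter, so the two cannot be told apart.

Compound 3 `COc1cc(C(=O)c2sc(-c3ccccc3)cc2N)cc(OC)c1OC` has not been measured. It differs from compound 1 by hydrogen in place of bromo on an aromatic carbon. For the measured compounds named here, the only measured step that bears on this, swapping one such group for another, was a 1.7-fold lower number from compound 1 to compound 2 (0.22 log units; within the scatter) and within the scatter; nothing shows what removing the group altogether does. The expectation is therefore a step of a 1.5-fold higher number from compound 1 to compound 3 (0.17 log units; within the scatter), modest and uncertain, leaning toward a somewhat higher number. Compound 3 is estimated at 220 nM, within 80 nM to 600 nM.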

Compound 3, half-maximal inhibitory concentration: 13 nM
Estimate against measurement, compound 3: 17-fold (1.23 log units) above; measured number below the stated range.
By their numbers in this assay, from the lowest: compound 3; then compounds 2 and 1 (each within the scatter of the next).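

Removing the group altogether matters far more at this position on the aromatic ring than exchanging one halogen for the other. In this assay, the change from 4-bromophenyl to phenyl gives a 12-fold lower number from compound 1 to compound 3 (1.06 log units; beyond the scatter), and hydrogen in place of chloro gives a 6.9-fold lower number from compound 2 to compound 3 (0.84 log units; beyond the scatter), so among these three compounds the plain phenyl gives the lowest number, and both halogens give clearly higher ones. The data at hand offer no explanation for this.

On these data alone, it remains open whether any other group on this carbon, such as fluoro, methoxy or an amine, could match hydrogen, or whether every addition here raises the number. It is also unknown whether the same order would hold outside this single cell assay.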